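The source may report more compounds than this note shows. Statements on the series, on what has been measured and on what is new or still open speak of the compounds shown alone.

In an ADME assay on isolated protein for inhibition of Amine oxidase [flavin-containing] B (Homo sapiens) (on this read-out higher numbers stand for weaker inhibition and lower numbers for stronger inhibition), compound 3 `C#CCNC1CCc2c(SCCc3cccc(Br)c3)cccc21` gives 620 nM, the second highest of the three numbers measured. Its nearest neighbour is compound 2 `C#CCNC1CCc2c(SCCc3cccc(C(F)(F)F)c3)cccc21`, which gives 280 nM, and the furthest is compound 1 `C#CCNC1CCc2c(SCCc3ccc(C)cc3)cccc21`, which gives 4520 nM. Compound 4 `C#CCNC1CCc2c(SCCc3cccc(OC)c3)cccc21` differs from compound 3 by methoxy in place of bromo on an aromatic carbon. Going by the values given here, two measured steps bear on swapping the group on this ring: a 2.2-fold higher number from compound 2 to compound 3 (0.35 log units; beyond the scatter), and a 7.3-fold lower number from compound 1 to compound 3 (0.86 log units; beyond the scatter). Neither covers methoxy itself, so the direction is uncertain, though such swaps have moved the number modestly in both directions. A modest rise is expected, a 1.9-fold higher number from compound 3 to compound 4 (0.29 log units; within the scatter). Compound 4 is estimated at 1200 nM, with a likely range from 400 nM to 3500 nM.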

Compound 4, half-maximal inhibitory concentration: 3820 nM
Estimate against measurement, compound 4: 3.2-fold (0.50 log units) below; the measured number lies above the stated range.
By their numbers in this assay, from the lowest: compound 2; then compound 3; then compounds 4 and 1 (each within the scatter of the next).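

Going by these compounds alone, at this ring carbon the choice of group matters more than the earlier compounds showed: in this assay methoxy brings a 6.2-fold higher number from compound 3 to compound 4 (0.79 log units; beyond the scatter) and also a 14-fold higher number from compound 2 to compound 4 (1.13 log units; beyond the scatter), a wider spread than bromo against trifluoromethyl alone. The 3-methoxyphenyl and 4-methylphenyl compounds cannot be told apart, with a 1.2-fold lower number from compound 1 to compound 4 (0.07 log units; within the scatter). Nothing available explains these differences. Still open, going by these compounds, is where a hydroxyl, a fluoro or a chloro group at this same carbon would fall. Also open, on these data alone, is whether an ethoxy group would follow methoxy.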